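Thiophen-2-yl in place of tert-butyl on a carbonyl carbon

A few compounds are considered here, and "the series" means these few. Any claim that something is new, unique, unknown or untested is made for them only; others in the source may bear on it.

In an ADME assay on HEK293 cells (Homo sapiens) for cytotoxicity, read by MTT assay, with a stated time of 48 h (a higher number here means a weaker inhibitor, a lower number a stronger inhibitor), compound 2 (`COc1ccc(-c2cn3cc(C4=CCN(C(=O)C(C)(C)C)CC4)ccc3n2)cc1OC`) gives 66600 nM. Compound 1 (`COc1ccc(-c2cn3cc(C4=CCN(S(=O)(=O)CCc5ccccc5)CC4)ccc3n2)cc1OC`) gives 70300 nM, and compound 3 (`COc1ccc(-c2cn3cc(C4=CCN(S(=O)(=O)c5ccccc5)CC4)ccc3n2)cc1OC`) gives 65600 nM, so all three values lie within the scatter of each other. Compound 4 (`COc1ccc(-c2cn3cc(C4=CCN(C(=O)c5cccs5)CC4)ccc3n2)cc1OC`) carries thiophen-2-yl in place of tert-butyl on a carbonyl carbon. Among the measured compounds shown here, no measured step makes this exact change. The closest ones alter the group on the amine nitrogen in a ring: a 1.1-fold lower number from compound 1 to compound 2 (0.02 log units; within the scatter), a 1.0-fold lower number from compound 2 to compound 3 (0.01 log units; within the scatter) and a 1.1-fold lower number from compound 1 to compound 3 (0.03 log units; within the scatter). Each stays within the scatter, so no step beyond the scatter is expected in this assay. The expected step is a 1.1-fold lower number from compound 2 to compound 4 (0.03 log units; within the scatter). The estimate for compound 4 is 62000 nM, with an expected range of 32000 nM to 100000 nM.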

Compound 4, half-maximal inhibitory concentration: 98100 nM
Compound 4: the middle estimate sits 1.6-fold (0.20 log units) below what was measured; the range from low to high includes it.
By their numbers in this assay, from the lowest: compounds 3, 2, 1 and 4 (each within the scatter of the next).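

In this assay a ring can stand on the carbonyl carbon without leaving the scatter: thiophen-2-yl in place of tert-butyl gives only a small step (a 1.5-fold higher number from compound 2 to compound 4 (0.17 log units; within the scatter)). Exchanging the whole group on the amine nitrogen in a ring for (thiophen-2-yl)carbonyl also stays within the scatter, whether phenylsulfonyl (a 1.5-fold higher number from compound 3 to compound 4 (0.17 log units; within the scatter)) or phenethylsulfonyl (a 1.4-fold higher number from compound 1 to compound 4 (0.14 log units; within the scatter)) leaves. Nothing measured here accounts for these readings. The compounds shown leave open whether a basic amine or a carboxylic acid carried on this carbonyl carbon would also stay within the scatter.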